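Working notes: thiophene attachment swap from compound 2 to compound 4

The source may hold more compounds than are shown below. What is called first, only, known or untested is meant among the compounds shown, and "the series" means these compounds.

Measured compounds:
- compound 1 `CC(=O)C1=C(C)NC(=O)NC1c1ccco1`: 30%
- compound 2 `CCOC(=O)C1=C(C)N(C)C(=O)NC1c1cccs1`: 2%
- compound 3 `CC1=C(C(=O)OC(C)C)C(c2cccs2)NC(=O)N1C`: 22%

In an assay on CHO cells for displacement of a labelled ligand from adenosine receptor A1 (Homo sapiens), with a stated time of 60 min, tested at 10 uM (on this read-out lower numbers stand for less inhibition and higher numbers for more inhibition at the one concentration tested (going by the name of the read-out)), compound 2 gives 2%, the lowest of the three numbers; compound 3 sits nearest, compound 1 furthest, both beyond the scatter. Among the compounds with values here, the one single-point step in the set is a number 20 percentage points higher from compound 2 to compound 3 (beyond the scatter), and it concerns the ester, not the aromatic ring. Compound 1 differs from compound 2 in several places at once, so its value is not a step.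

Compound 4 `CCOC(=O)C1=C(C)N(C)C(=O)NC1c1ccsc1` is the next compound for this assay. It differs from compound 2 only as follows: thiophen-3-yl in place of thiophen-2-yl on a saturated ring carbon.

Within the data shown here, no measured pair in the set changes the thiophene attachment, so there is no step that bears directly on this change. The expectation therefore rests on compound 2 alone and is set close to its value, with room for a modest rise. For compound 4 the expected step is a number 6 percentage points higher from compound 2 to compound 4 (within the scatter), which lies within the scatter. Compound 4 is estimated at 8%, in the range 0% to 22%.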

Compound 4, a percentage reported as inhibition, at one concentration (the size of the read-out at that concentration, not a potency): 30%
Estimate against measurement, compound 4: 22 percentage points below; measured number outside the range, above it.
By their numbers in this assay, from the lowest: compound 2; then compounds 3, 1 and 4 (each within the scatter of the next).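

In this assay, the saturated ring carbon proves sensitive to how the thiophene is attached, with a number 28 percentage points higher from compound 2 to compound 4 (beyond the scatter). The atom counts printed for thiophen-2-yl and thiophen-3-yl are identical, and the ethoxycarbonyl group and both methyl groups stay in place, so the low number of compound 2 at 2% does not extend to every thiophene on this core. Nothing available explains the step.

As far as these compounds go, whether thiophen-3-yl in place of thiophen-2-yl gives a similar step alongside the isopropyl ester of compound 3 remains open. The compounds shown also leave open how a phenyl or pyridine ring, or a thiophene carrying a chlorine atom, would read on this same saturated ring carbon.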